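This account rests on a few compounds, and the source may have more. Where it says the series, first, only, none or still open, it means among the compounds named here.

Working notes on a small set of sulfonamides built on two related cores.

Compound 1, `O=[N+]([O-])c1ccc(S(=O)(=O)Nc2cccc3c(Cl)c[nH]c23)cc1`, is the reference for the first core. In a functional assay on P388 cells (Mus musculus) for antiproliferative activity, read by colorimetric assay and MTT assay (a higher number here means a weaker inhibitor, a lower number a stronger inhibitor), compound 1 gives 2.3 ug/mL. Compound 2, `O=[N+]([O-])c1ccc(S(=O)(=O)Nc2ccc(Cl)c3cc[nH]c23)cc1`, carries the same atoms joined differently; the difference between the two cores is not broken down here. In this assay compound 2 gives 3.3 ug/mL, a value within the scatter of that of compound 1, so the two cores are not separated by these data. Compound 3, `N#Cc1ccc(S(=O)(=O)Nc2cccc3c(Cl)c[nH]c23)cc1`, is compound 1 with cyano in place of nitro on an aromatic carbon. In this assay compound 3 gives 1.4 ug/mL. For the measured compounds named here, the step of a 1.6-fold lower number from compound 1 to compound 3 (0.22 log units; within the scatter) is the only measured instance of this change in the set. The gap between compound 2 and compound 3 is beyond the scatter, but the two differ in both the core and the substituent, so it is not assigned to either.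

Compound 4, `N#Cc1ccc(S(=O)(=O)Nc2ccc(Cl)c3cc[nH]c23)cc1`, is not yet measured. It stands to compound 2 as compound 3 stands to compound 1: cyano in place of nitro on an aromatic carbon, the same change at the same place. Going by the values given here, the expectation for compound 4 in this assay rests on the single measured step of a 1.6-fold lower number from compound 1 to compound 3 (0.22 log units; within the scatter), transferred to the core of compound 2. On that basis, compound 4 is expected to show a step of a 1.6-fold lower number from compound 2 to compound 4 (0.20 log units; within the scatter) in this assay. The estimated value for compound 4 is 2.1 ug/mL, with a range from 1 ug/mL to 4.5 ug/mL expected, since one prior step carries little weight.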

Compound 4, half-maximal inhibitory concentration: 1.8 ug/mL
The estimate for compound 4 lay 1.2-fold (0.07 log units) above the measured number; measured number inside the range.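

In this assay, cyano in place of nitro on an aromatic carbon gives a 1.8-fold lower number from compound 2 to compound 4 (0.26 log units; within the scatter), so on this core, as on the core of compound 1, the change does not separate the two compounds it joins. The two cores can be set side by side, and the change reads the same on both within the limits of the data: the same change on two cores in this assay, a 1.6-fold lower number (0.22 log units; within the scatter) from compound 1 to compound 3 and a 1.8-fold lower number (0.26 log units; within the scatter) from compound 2 to compound 4, 1.1-fold (0.05 log units) apart, within the scatter of two such steps. This shows that, for these two cores, a step measured on one was a fair guide to the step on the other, but it does not show that cyano and nitro truly differ in this assay, since each step on its own stays within the scatter, and two instances of a single change establish no rule for other cores or other substituents.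

The compounds shown leave open how an amine, a carboxylic acid or a methoxy group would read on the same aromatic carbon, para to the large group, where only nitro and cyano appear so far. They also leave open whether a group that gives a step beyond the scatter on one core would carry over to the other as closely as this change does.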